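Removing the second chloro from the core of compound 1

The compounds below may be only part of what the source reports. "The series", "measured", "known", "first", "only" and "open" are said of these compounds alone.

Compound 1 `ClCc1cccc(Cn2cnc3c(Cl)nc(Cl)nc32)c1` and compound 2 `ClCc1ccc(Cn2cnc3c(Cl)nc(Cl)nc32)cc1` share a dichlorinated core and differ only in where the chloromethyl group sits on the benzyl ring. In a functional assay on OVCAR-5 cells (Homo sapiens) for cytotoxicity, read by sulforhodamine B assay, with a stated time of 48 h (a higher number here means a weaker inhibitor of growth, a lower number a stronger inhibitor of growth), compound 1 gives 6450 nM and compound 2 gives 18200 nM, so compound 1 holds the lower of the two numbers, beyond the scatter. Compound 3 `ClCc1cccc(Cn2cnc3c(Cl)ncnc32)c1` keeps the benzyl pattern of compound 1; its change from compound 1 is hydrogen in place of chloro on an aromatic carbon. Within the data shown here, no measured step shows this change. A modest rise in the number is expected, with a step of a 1.7-fold higher number from compound 1 to compound 3 (0.23 log units; within the scatter) in this assay, so compound 3 is estimated at 11000 nM within 3500 nM to 35000 nM.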

Compound 3, concentration for 50% growth inhibition: 2080 nM
Estimate against measurement, compound 3: 5.3-fold (0.72 log units) above, and the stated range ends above it.
By their numbers in this assay, from the lowest: compound 3; then compound 1; then compound 2.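

The chloro on the aromatic carbon between two ring nitrogen atoms is not required for growth inhibition in this assay: hydrogen in its place gives a 3.1-fold lower number from compound 1 to compound 3 (0.49 log units; beyond the scatter), a modest step beyond the scatter. Among these compounds, compound 1 and compound 2 differ only on the benzyl ring, so this is the first reading at this core position. Nothing available explains the step. On these data alone, whether an amine or a methoxy group on this carbon would keep the lower number remains open, as does whether the same change holds with the benzyl pattern of compound 2.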